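Cyano-fluorophenyl for difluorophenyl on the aromatic carbon

This account rests on a few compounds, and the source may have more. Where it says the series, first, only, none or still open, it means among the compounds named here.

Among the compounds with values here, compound 2 `O=C(O)Cc1sc(C(c2ccc(F)cc2)c2ccc(F)cc2)nc1-c1cc(F)cc(F)c1` stands highest of the two numbers so far in an in vitro functional assay on HEK285-7 cells for antagonist activity at prostaglandin D2 receptor 2 (Homo sapiens), read by BRET and beta-arrestin recruitment (a lower number here means a smaller maximal response, a higher number a larger maximal response), where compound 2 gives 80%. Within the data shown here, compound 1 `Nc1nc(-c2ccc(Cl)cc2)c(CC(=O)O)s1` gives 50% in this assay, a number lower by more than the usual scatter; the two differ in several places, so no single step is drawn between them. Compound 3 `N#Cc1cc(-c2nc(C(c3ccc(F)cc3)c3ccc(F)cc3)sc2CC(=O)O)ccc1F` is not yet measured. It differs from compound 2 by 3-cyano-4-fluorophenyl in place of 3,5-difluorophenyl on an aromatic carbon. Among the measured compounds shown here, no measured step of this kind exists. The change is expected to move the maximal response little, no change at the digits printed from compound 2 to compound 3 (within the scatter), staying within the scatter. Compound 3 is therefore estimated at 80% in this assay, with an expected range of 62% to 95%.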

Compound 3, largest response reached (reported as efficacy), in percent of the reference or control that the assay uses: 80%
Compound 3: middle estimate and measured number agree at the digits printed, and the stated range covers the measured number.
By their numbers in this assay, from the lowest: compound 1; then compounds 2 and 3 (each within the scatter of the next).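

In this assay, within the data shown here, the swap of 3,5-difluorophenyl for 3-cyano-4-fluorophenyl gives no change at the digits printed from compound 2 to compound 3 (within the scatter) and is the first step read at this position, on the aromatic carbon next to the ring nitrogen. For this pair, the maximal response does not require 3,5-difluorophenyl there, and a phenyl ring bearing a nitrile serves equally. No evidence bears on why the response holds. The compounds shown leave open whether it also holds with an amine or a propyl chain in place of the phenyl ring at this carbon.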